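Fluorophenyl Placement and Cytotoxicity in Rhabdomyosarcoma Cells

The source may report more compounds than this note shows. Statements on the series, on what has been measured and on what is new or still open speak of the compounds shown alone.

compound 1 `Fc1ccc(/C=N/c2sc3c(c2-c2nc4ccccc4s2)CCC3)cc1`: 290 ug/mL
compound 2 `Fc1ccc(/C=N/c2sc3c(c2-c2nc4ccccc4s2)CCCC3)cc1`: 230 ug/mL

In an ADME assay on cells (Rhabdomyosarcoma cell, Homo sapiens) for cytotoxicity, read by MTT assay, with a stated time of 72 h (on this read-out higher numbers stand for lower toxicity in this test and lower numbers for higher toxicity in this test), compound 1 gives 290 ug/mL, while compound 2 gives 230 ug/mL. Compound 2 carries the lower of the two numbers, but its nearest neighbour, compound 1, lies within the scatter, so no order can be read between the two. Compound 3 `Fc1ccccc1/C=N/c1sc2c(c1-c1nc3ccccc3s1)CCCC2` differs from compound 2 by 2-fluorophenyl in place of 4-fluorophenyl on a carbon with a double bond to nitrogen. Among the compounds with values here, no measured pair shows such a change, so the expected step in this assay is none beyond the scatter. Compound 3 is therefore expected to give 220 ug/mL, within a range from 110 ug/mL to 450 ug/mL. The estimated step of a 1.0-fold lower number from compound 2 to compound 3 (0.02 log units; within the scatter) is expected to be small.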

Compound 3, half-maximal cytotoxic concentration: 319 ug/mL
Beside the measured number, compound 3's estimate is 1.5-fold (0.16 log units) below it; the measured number falls inside the stated range.
By their numbers in this assay, from the lowest: compounds 2, 1 and 3 (each within the scatter of the next).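

The exchange of 4-fluorophenyl for 2-fluorophenyl on a carbon with a double bond to nitrogen is the first change shown at this position, and in this assay it gives a 1.4-fold higher number from compound 2 to compound 3 (0.14 log units; within the scatter) and so leaves no readable difference. For this pair, moving the fluorine around the phenyl ring does not shift the read-out beyond the scatter. No measurement bears on why this is so.

On these data alone, whether an amine or a carboxylic acid on this phenyl ring would shift the number remains open. So does the effect of replacing the phenyl ring with a longer chain.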